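From a hydroxy to a methyl group in growth inhibition

This account rests on a few compounds, and the source may have more. Where it says the series, first, only, none or still open, it means among the compounds named here.

Compound 1 `Cc1ccc2[nH]c(-c3ccc(-c4ccc(-c5cccc(Cl)c5)cc4)cc3)nc2c1` gives 2670 nM
Compound 2 `Oc1cccc2[nH]c(-c3ccc(-c4ccc(-c5ccc(C(F)(F)F)cc5)cc4)cc3)nc12` gives 2260 nM

In a functional assay on PC-3 cells (Homo sapiens) for inhibition, read by sulforhodamine B assay (a lower number here means a stronger inhibitor of growth, a higher number a weaker inhibitor of growth), compound 2 gives 2260 nM and stands within the usual scatter of compound 1. Compound 3 `Cc1ccc2[nH]c(-c3ccc(-c4ccc(-c5ccc(C(F)(F)F)cc5)cc4)cc3)nc2c1` has 5-methyl-1H-benzimidazol-2-yl in place of 4-hydroxy-1H-benzimidazol-2-yl on an aromatic carbon and awaits measurement. Going by the values given here, no measured pair isolates this change. Compound 1, which also carries 5-methyl-1H-benzimidazol-2-yl, gives 2670 nM in this assay, so no step beyond the scatter is expected. The expected change is a 1.2-fold higher number from compound 2 to compound 3 (0.06 log units; within the scatter) in this assay. For compound 3 the estimated value is 2600 nM (range 1100 nM to 6000 nM).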

Compound 3, concentration for 50% growth inhibition: 2010 nM
For compound 3 the middle estimate is 1.3-fold (0.11 log units) above the measured one, within the range that was stated.
By their numbers in this assay, from the lowest: compounds 3, 2 and 1 (each within the scatter of the next).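

In this assay the exchange of 4-hydroxy-1H-benzimidazol-2-yl for 5-methyl-1H-benzimidazol-2-yl comes to a 1.1-fold lower number from compound 2 to compound 3 (0.05 log units; within the scatter) and lies within the scatter, so at this position the change leaves growth inhibition unmoved. Putting 4-(trifluoromethyl)phenyl in place of 3-chlorophenyl comes to a 1.3-fold lower number from compound 1 to compound 3 (0.12 log units; within the scatter) and also lies within the scatter, so neither single change separates these compounds. Nothing available accounts for either result.

As far as these compounds go, whether an amine or a carboxylic acid at the place of the methyl would move the number beyond the scatter remains open.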